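The source may hold more compounds than are shown below. What is called first, only, known or untested is meant among the compounds shown, and "the series" means these compounds.

Measured so far in an assay on isolated protein for binding affinity to Equilibrative nucleoside transporter 1 (Homo sapiens); a lower number here means a stronger inhibitor, a higher number a weaker inhibitor:
Compound 1 `Nc1nc(SCc2ccc(Br)cc2)c2ncn([C@@H]3O[C@H](CO)[C@@H](O)[C@H]3O)c2n1` gives 813 nM.
Compound 2 `CCCCn1cnc2c(SCc3ccccn3)nc(N)nc21` gives 52500 nM.
Compound 3 `CCCC(C)n1cnc2c(SCc3ccccn3)nc(N)nc21` gives 41700 nM.

Going by the values given here, compound 3 stands second highest of the three numbers; compound 2 sits within the scatter of it, and the only measured single step, a 1.3-fold lower number from compound 2 to compound 3 (0.10 log units; within the scatter), is within the scatter. Among the compounds with values here, compound 1, at 813 nM, lies far below compound 3, but the two differ in two places, so no single step isolates either change.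

Compound 4 `Nc1nc(SCc2ccccn2)c2ncn([C@@H]3O[C@H](CO)[C@@H](O)[C@H]3O)c2n1` is compound 3 with 3,4-dihydroxy-5-(hydroxymethyl)oxolan-2-yl in place of 1-methylbutyl on an aromatic nitrogen. Within the data shown here, no measured step bears on this change; compound 1 is the only compound carrying the same sugar, and its low number in this assay is the sole pointer. A large drop toward compound 1 is therefore expected, with wide uncertainty because compound 1 gives 813 nM with a different thioether group. The expected step is a 14-fold lower number from compound 3 to compound 4 (1.14 log units; beyond the scatter). Compound 4 is estimated at 3000 nM, range 500 nM to 20000 nM.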

Compound 4, half-maximal inhibitory concentration: 34700 nM
Compound 4: the middle estimate sits 12-fold (1.06 log units) below what was measured; measured number above the stated range.
By their numbers in this assay, from the lowest: compound 1; then compounds 4, 3 and 2 (each within the scatter of the next).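

In this assay, 3,4-dihydroxy-5-(hydroxymethyl)oxolan-2-yl on the aromatic nitrogen stands level with both chains while pyridin-2-yl sits on the thioether carbon: a 1.2-fold lower number from compound 3 to compound 4 (0.08 log units; within the scatter) for 1-methylbutyl and a 1.5-fold lower number from compound 2 to compound 4 (0.18 log units; within the scatter) for butyl. With that group held constant, the change on the saturated chain carbon bound to sulfur gives a 43-fold higher number from compound 1 to compound 4 (1.63 log units; beyond the scatter) for pyridin-2-yl in place of 4-bromophenyl. No evidence on the cause of either result is available.

On these data alone, whether 4-bromophenyl keeps its low number with butyl or 1-methylbutyl on the nitrogen remains open. So does the outcome with 4-chlorophenyl or unsubstituted phenyl on the thioether carbon.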